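Butyl to Benzyl on an Amide-Type Nitrogen

This account rests on a few compounds, and the source may have more. Where it says the series, first, only, none or still open, it means among the compounds named here.

Of the compounds shown here, three built on one shared core have been measured in an assay (Cavia porcellus) for inhibition of Polyunsaturated fatty acid 5-lipoxygenase (Homo sapiens); on this read-out lower numbers stand for stronger inhibition and higher numbers for weaker inhibition. Compound 1 `NC(=S)N(O)CC1=Cc2cc(Oc3ccccc3)ccc2OC1` gives 200 nM. Compound 2 `CC(C)NC(=O)N(O)CC1=Cc2cc(Oc3ccccc3)ccc2OC1` gives 63 nM, and compound 3 `CCCCNC(=O)N(O)CC1=Cc2cc(Oc3ccccc3)ccc2OC1` gives 69 nM. Compound 3 thus stands second highest of the three numbers: the steps of a 3.2-fold lower number from compound 1 to compound 2 (0.50 log units; beyond the scatter) and a 2.9-fold lower number from compound 1 to compound 3 (0.46 log units; beyond the scatter) both reach beyond the scatter, whereas the step of a 1.1-fold higher number from compound 2 to compound 3 (0.04 log units; within the scatter) stays within it, so compound 2 and compound 3 cannot be told apart on these numbers.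

Compound 4 `O=C(NCc1ccccc1)N(O)CC1=Cc2cc(Oc3ccccc3)ccc2OC1` differs from compound 3 in one place: phenyl in place of propyl on a saturated chain carbon bound to an amide-type nitrogen. Within the data shown here, the only measured step that touches this end of the molecule is a 1.1-fold higher number from compound 2 to compound 3 (0.04 log units; within the scatter), which exchanged one chain for another without a change beyond the scatter. Among the measured compounds shown here, no measured step exchanges a chain for a ring, so the data give no ground to expect a shift either way, and the expected step is a 1.2-fold lower number from compound 3 to compound 4 (0.06 log units; within the scatter). Compound 4 is therefore estimated at 60 nM in this assay, with a range from 25 nM to 150 nM.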

Compound 4, half-maximal inhibitory concentration: 440 nM
Compound 4: middle estimate off by 7.3-fold (0.87 log units), on the low side; measured number above the stated range.
By their numbers in this assay, from the lowest: compounds 2 and 3 (each within the scatter of the next); then compound 1; then compound 4.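

In this assay the place on a saturated chain carbon bound to an amide-type nitrogen did not stay indifferent once a ring entered: phenyl in place of propyl gave a 6.4-fold higher number from compound 3 to compound 4 (0.80 log units; beyond the scatter) and benzyl in place of isopropyl gave a 7.0-fold higher number from compound 2 to compound 4 (0.84 log units; beyond the scatter) even though butyl and isopropyl had stood within the scatter of each other. With a 2.2-fold higher number from compound 1 to compound 4 (0.34 log units; beyond the scatter) as well, the lower numbers seen with those two chains do not extend to every group on this nitrogen. Nothing measured here accounts for this shift.

The compounds shown leave open whether a cyclohexylmethyl group, with a saturated ring, would follow compound 4 or the chains of compound 2 and compound 3. They also leave open how a phenethyl group, with its longer link to the phenyl ring, would read.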